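The source may report more compounds than this note shows. Statements on the series, on what has been measured and on what is new or still open speak of the compounds shown alone.

The measured compounds in this study are three:

compound 1, `COc1cc(/C=C/c2ccc(C(C)(C)C)cc2)cc(OC)c1OC`, which in a functional assay on MLM cells (Homo sapiens) for cytotoxicity, using microsomes (a higher number here means that more compound is needed for the effect, a lower number that less compound is needed), gives > 25 uM
compound 2, `COc1ccc(C(O)c2cc(OC)c(OC)c(OC)c2)cc1`, which in this assay gives 16.8 uM
compound 3, `COC(=O)/C(=C/c1cccc(OC)c1)c1cc(OC)c(OC)c(OC)c1`, which in this assay gives 15.5 uM

The account follows compound 1. Its result in this assay is not a number but a limit of the assay: compound 1 sits at the limit of > 25 uM in this assay, at which 1 of the 3 values shown sits, so only a lower bound for the concentration at half-maximal effect is known. Compound 2 and compound 3 give numbers, and those two numbers lie within the usual scatter of each other. Going by the values given here, no pair of measured compounds here differs in a single place, so no measured step exists from which the weight of a small change could be read off.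

The next compound is compound 4, `COc1cc(/C=C/c2ccc(C(C)C)cc2)cc(OC)c1OC`. It differs from compound 1 by hydrogen in place of methyl on a saturated chain carbon bound to an aromatic carbon and two saturated chain carbons. The change is small: the part of the molecule that is altered keeps its place, and only one heavy atom is lost. Among the compounds with values here, with no measured step to anchor it, the expected step in this assay from compound 1 to compound 4, a step that the limit leaves unreadable from compound 1 to compound 4, is none beyond the scatter. For compound 4 the estimate in this assay is therefore 30 uM, with a range from 12 uM to 80 uM, and a fair chance that the assay again reports only a limit rather than a number.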

Compound 4, concentration for half-maximal effect: > 25 uM
Compound 4 was reported as a limit (the forecaster's own chance of this, stated with the estimate: 55%); the middle value is on the limit's open side.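

Compound 1 and compound 4 both stand at a limit of this assay rather than at a number, so no step between them can be read, and the change from tert-butyl to isopropyl has no readable size: the limit of > 25 uM in this assay, at which 2 of the 4 values shown sit.

The compounds shown leave open how far above that limit either compound lies, and what the change from tert-butyl to isopropyl does in this assay.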